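The source may hold more compounds than are shown below. What is called first, only, known or untested is meant among the compounds shown, and "the series" means these compounds.

In an assay on isolated protein for inhibition of tyrosine-protein kinase Mer (Homo sapiens), read by LC-MS (a higher number here means a weaker inhibitor, a lower number a stronger inhibitor), compound 1 `CN(Cc1ccc2nccn2c1)c1nnc(-c2ccc(-c3ccccc3F)cc2)o1` gives 15.9 nM, compound 2 `CN(Cc1ccc2nccn2c1)c1nnc(-c2ccc(-c3ccccc3C#N)cc2)o1` gives 25.1 nM, and compound 3 `Cc1nn(C)c(C)c1-c1ccc(-c2nnc(N(C)Cc3ccc4nccn4c3)o2)cc1` gives 31.6 nM. The three numbers sit close together: the step of a 2.0-fold higher number from compound 1 to compound 3 (0.30 log units; within the scatter) and the step of a 1.3-fold higher number from compound 2 to compound 3 (0.10 log units; within the scatter) both lie within the scatter, so compound 3 stands alongside the other two rather than apart from them. Compound 4 `Cc1nn(C)c(C)c1-c1ccc(-c2nnc(N(C)Cc3ccc4nccn4c3)o2)c(F)c1` differs from compound 3 by one change, (fluoro in place of hydrogen on an aromatic carbon). Within the data shown here, none of the measured steps touches this ring position; the steps that exist, such as a 1.6-fold higher number from compound 1 to compound 2 (0.20 log units; within the scatter), swap groups on the outer ring and were all within the scatter. Nothing here points to a shift beyond the scatter in this assay. Compound 4 is therefore expected to give 30 nM, in the range 12 nM to 80 nM, an estimated step of a 1.1-fold lower number from compound 3 to compound 4 (0.02 log units; within the scatter).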

Compound 4, half-maximal inhibitory concentration: 12.6 nM
The estimate for compound 4 lay 2.4-fold (0.38 log units) above the measured number; low and high end bracket the measured number.
By their numbers in this assay, from the lowest: compounds 4, 1, 2 and 3 (each within the scatter of the next, the first and the last beyond it).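

In this assay, the step of a 2.5-fold lower number from compound 3 to compound 4 (0.40 log units; beyond the scatter) is the only one so far that lies beyond the scatter. Among these compounds, it comes from a single fluoro on an aromatic carbon ortho to a large group, so this position, untouched by the earlier steps, can shift the number even though the swaps on the outer ring did not. Nothing measured here explains the shift.

On these data alone, whether a chloro or methoxy group in the same place would act alike stays open. So does whether the fluoro would have the same effect with a 2-fluorophenyl or 2-cyanophenyl group in place of the 1,3,5-trimethyl-1H-pyrazol-4-yl group.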